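The source may hold more compounds than are shown below. What is called first, only, known or untested is meant among the compounds shown, and "the series" means these compounds.

Of the compounds shown here, three built on one shared core have been measured in a functional assay with sulfonylurea receptors; K-ATP channels (Homo sapiens) as the target; on this read-out lower numbers stand for an effect already at smaller amounts and higher numbers for an effect only at larger amounts of compound. Compound 1 `CC(C)(C)C(NC(=O)c1ccc(Cl)cc1)N/C(S)=N/c1cccnc1` gives 7940 nM. Compound 2 `CC(C)(C)C(NC(=O)c1ccc(Cl)cc1)N/C(=N/c1cccnc1)NC#N` gives 20000 nM, the highest of the three numbers. Compound 3 `CC(C)(C)C(NC(=O)c1ccc(Cl)cc1)N/C(=N/c1cccnc1)N[N+](=O)[O-]` gives 7940 nM. Three steps between them are known: a 2.5-fold higher number from compound 1 to compound 2 (0.40 log units; beyond the scatter), no change at the digits printed from compound 1 to compound 3 (within the scatter) and a 2.5-fold lower number from compound 2 to compound 3 (0.40 log units; beyond the scatter). All three steps exchange the group on the carbon with a double bond to nitrogen; the tert-butyl group stays the same throughout.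

Compound 4 `CCC(CC)(CCC#N)C(NC(=O)c1ccc(Cl)cc1)N/C(=N/c1cccnc1)NC#N` differs from compound 2 at a different place: 1-(2-cyanoethyl)-1-ethylpropyl in place of tert-butyl on a saturated chain carbon bound to an amide-type nitrogen and an amine nitrogen. Among the measured compounds shown here, none of the measured steps touches this position, so no measured step bears on this change directly, and the data give no guidance on how a larger group here affects the read-out. The expectation therefore rests on compound 2 alone, with wide uncertainty in either direction. The step from compound 2 to compound 4 is expected to be no change at the digits printed from compound 2 to compound 4 (within the scatter). For compound 4 in this assay the estimate is 20000 nM, expected to lie between 5000 nM and 80000 nM.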

Compound 4, half-maximal effective concentration: 5010 nM
Estimate against measurement, compound 4: 4.0-fold (0.60 log units) above; low and high end bracket the measured number.
By their numbers in this assay, from the lowest: compounds 4, 1 and 3 (each within the scatter of the next); then compound 2.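

At this position, on a saturated chain carbon bound to an amide-type nitrogen and an amine nitrogen, the group can be changed with a clear effect in this assay. Replacing tert-butyl with the larger 1-(2-cyanoethyl)-1-ethylpropyl, which also carries a nitrile, gives a 4.0-fold lower number from compound 2 to compound 4 (0.60 log units; beyond the scatter), so here the larger group goes with a lower number, not a higher one. No available measurement shows what lies behind this shift.

The compounds shown cannot separate the contribution of the added carbon atoms from that of the nitrile; an all-carbon chain ending in a methyl group in place of the 2-cyanoethyl arm would address this. Going by these compounds, it also remains open whether the same exchange would have a similar effect with sulfanyl or nitroamino on the carbon with a double bond to nitrogen.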